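Compound 3 to compound 4: pyrimidin-2-yl replaces 1-hydroxyethyl

The source may report more compounds than this note shows. Statements on the series, on what has been measured and on what is new or still open speak of the compounds shown alone.

In an in vivo ADME assay on the whole organism (strain 129/SvEvBrd x C57BL/6) for pharmacokinetics, with Mus musculus as the target (a higher number here means that a larger share of the oral dose reaches the circulation, a lower number that a smaller share of the oral dose reaches the circulation), compound 3 `CC(O)c1nc([C@@H](O)[C@H](O)[C@H](O)CO)c[nH]1` gives 22%. That lies within the scatter of compound 1 `CCc1[nH]c(C(C)=O)nc1[C@@H](O)[C@H](O)[C@H](O)CO` at 17.1%, and well short of compound 2 `CC(=O)c1nc([C@@H](O)[C@H](O)[C@H](O)CO)c(-c2ccccc2)[nH]1` at 49.6%, a gap beyond the scatter.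

The next compound is compound 4 `OC[C@@H](O)[C@@H](O)[C@H](O)c1c[nH]c(-c2ncccn2)n1`. The change is pyrimidin-2-yl in place of 1-hydroxyethyl on an aromatic carbon, between two ring nitrogen atoms.

Among the measured compounds shown here, only one measured step bears on this change, and only indirectly: a number 32.5 percentage points higher from compound 1 to compound 2 (beyond the scatter), a large step with phenyl in place of ethyl on an aromatic carbon. That step also brings in a six-membered aromatic ring. However, it does not remove 1-hydroxyethyl, and no measured compound carries pyrimidin-2-yl. The comparison is therefore weak, and only part of the rise seen in compound 2, at 49.6%, is expected to carry over.

In this assay, the expected change is a modest rise, with an estimated step of a number 8 percentage points higher from compound 3 to compound 4 (within the scatter). The range is kept wide, since it rests on a single indirect comparison. For compound 4 the estimated value is 30%, with an expected range of 12% to 55%.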

Compound 4, oral bioavailability: 7%
Compound 4: the middle estimate sits 23 percentage points above what was measured; measured number below the stated range.
By their numbers in this assay, from the lowest: compound 4; then compounds 1 and 3 (each within the scatter of the next); then compound 2.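

In this assay, among the compounds shown here, exchanging 1-hydroxyethyl for pyrimidin-2-yl on the aromatic carbon between two ring nitrogen atoms gives a number 15 percentage points lower from compound 3 to compound 4 (beyond the scatter), the only measured change at this position so far, and it shows that the value here responds to the group carried at this place. The earlier step, a number 32.5 percentage points higher from compound 1 to compound 2 (beyond the scatter), also brought in a six-membered aromatic ring, but with phenyl in place of ethyl at another place and on a different compound pair, so the two steps together show that such a ring does not bring a rise wherever it enters. The change also replaces a group with a hydrogen-bond donor by one with none, and nothing in hand explains the fall or ties it to that difference.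

Still open, on these data alone, is whether a plain phenyl, an amine or a carboxylic acid on this aromatic carbon would stay closer to the value of 1-hydroxyethyl, which would help separate the loss of the hydroxyl from the arrival of the ring. Also open, as far as these compounds go, is whether pyrimidin-2-yl would give a step of similar size on a core carrying ethyl or phenyl on the other aromatic carbon.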